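The source may hold more compounds than are shown below. What is called first, only, known or untested is meant among the compounds shown, and "the series" means these compounds.

In a functional assay on HT-29 cells (Homo sapiens) for antiproliferative activity, read by MTT assay, with a stated time of 72 h (a lower number here means a stronger inhibitor, a higher number a weaker inhibitor), the measurements so far are these:

- compound 1 `COc1ccc(N2CCN(C(=S)SCc3ccc4nc(N)nc(N)c4c3)CC2)cc1` gives 1770 nM
- compound 2 `Nc1nc(N)c2cc(CSC(=S)N3CCN(c4ccccc4Cl)CC3)ccc2n1` gives 3900 nM

Compound 2 at 3900 nM has the higher of the two numbers, which makes it the weaker inhibitor of the pair. Compound 3 `Nc1nc(N)c2cc(CSC(=S)N3CCN(c4ccc(F)cc4)CC3)ccc2n1` has not yet been measured. It differs from compound 2 in one place, with 4-fluorophenyl in place of 2-chlorophenyl on an amine nitrogen in a ring.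

Among the compounds with values here, only one measured step bears on this change. That step, a 2.2-fold higher number from compound 1 to compound 2 (0.34 log units; beyond the scatter), is modest and replaces 4-methoxyphenyl with the same 2-chlorophenyl group on that same nitrogen. Within the data shown here, compound 3 loses this 2-chlorophenyl group, so a modest move back towards a lower number seems the likeliest outcome, but no measured compound carries a 4-fluorophenyl group, and one step is thin evidence. The expected change is a 1.6-fold lower number from compound 2 to compound 3 (0.19 log units; within the scatter) in this assay. For compound 3 the estimated value is 2500 nM, with an expected range from 1000 nM to 6000 nM in this assay.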

Compound 3, half-maximal inhibitory concentration: 2050 nM
Compound 3: the middle estimate sits 1.2-fold (0.09 log units) above what was measured, and the stated range covers the measured number.
By their numbers in this assay, from the lowest: compounds 1, 3 and 2 (each within the scatter of the next, the first and the last beyond it).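

In this assay the swap of 2-chlorophenyl for 4-fluorophenyl on the amine nitrogen in the ring gives a 1.9-fold lower number from compound 2 to compound 3 (0.28 log units; within the scatter) and so cannot be told apart from noise, while fluoro in place of methoxy on the aromatic carbon gives a 1.2-fold higher number from compound 1 to compound 3 (0.06 log units; within the scatter) and is equally unresolved. Compound 3 therefore cannot be separated from either earlier compound, even though the earlier pair is resolved by a 2.2-fold higher number from compound 1 to compound 2 (0.34 log units; beyond the scatter) and this position has now carried three different substituted phenyl groups with only small shifts in the number. Nothing measured on these compounds accounts for these small differences.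

Compound 2 and compound 3 differ in both the halogen and where it stands on the phenyl ring, so a 4-chlorophenyl group would be needed to separate those two changes. The compounds shown also leave open how far this nitrogen tolerates something other than a singly substituted phenyl group, such as an unsubstituted phenyl, a phenyl bearing a carboxylic acid or a simple methyl group.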